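A Hydroxy-for-Methylsulfanyl Swap Across Two Cores

The source may hold more compounds than are shown below. What is called first, only, known or untested is meant among the compounds shown, and "the series" means these compounds.

Four compounds built on two related cores are considered. Compound 1 `CSc1nncc2c(C)nc(C(C)C)n12` carries a methylsulfanyl group, and compound 2 `Cc1nc(C(C)C)n2c(O)nncc12` is its hydroxy counterpart; compound 3 `CCCc1ncc2cnnc(SC)n12` carries the methylsulfanyl group on the second core, and compound 4 `CCCc1ncc2cnnc(O)n12` is the matching hydroxy compound that has not yet been tested.

In a functional assay for inhibition, with Homo sapiens as the target (a lower number here means a stronger inhibitor, a higher number a weaker inhibitor), compound 1 gives > 48000 nM, which is a limit of the assay rather than a number. Compound 2 likewise gives > 48000 nM in this assay, again only a limit. Compound 3 gives > 48000 nM in this assay, also a limit. Because all three values sit at the limit of > 48000 nM in this assay, at which 3 of the 3 values shown sit, the change from compound 1 to compound 2, namely (hydroxy in place of methylsulfanyl on an aromatic carbon), is a step that the two limits leave unreadable from compound 1 to compound 2.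

The difference between the two cores is not broken down here. Among the compounds with values here, the change from compound 3 to compound 4 is hydroxy in place of methylsulfanyl on an aromatic carbon, which is the same change as the one from compound 1 to compound 2, made at an identically described place.

Since compound 3 shows only the limit > 48000 nM and the earlier example of this change gave no readable step, compound 4 is expected to stay close to the limit, with an expected step that the limit leaves unreadable from compound 3 to compound 4 in this assay. The estimate for compound 4 in this assay is 60000 nM, expected to fall between 20000 nM and 200000 nM, and most likely reported again only as a limit.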

Compound 4, half-maximal inhibitory concentration: > 48000 nM
Compound 4: no number, only a limit; the forecaster's own chance of this, stated with the estimate: 85%; the middle value lies beyond the limit too.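

In this assay compound 4 gives > 48000 nM as a limit of the assay and not a number. No step can be read from compound 3 to compound 4 or between any other compounds shown, because every value is a limit: the limit of > 48000 nM in this assay, at which 4 of the 4 values shown sit. The compounds shown leave open how strongly any of them inhibits, and whether hydroxy in place of methylsulfanyl changes activity on either core.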